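The compounds below may be only part of what the source reports. "The series", "measured", "known", "first", "only" and "open" are said of these compounds alone.

Working notes on the series.

Compound 1 `COc1cc2ncnc(NNC(=S)NC(=O)c3ccccc3OC)c2cc1OC` and compound 2 `COc1cc2ncnc(NNC(=S)NC(=O)c3ccc(F)cc3)c2cc1OC` share one core; compound 3 `COc1ccccc1C(=O)NC(=S)NNc1ncnc2ccccc12` and compound 4 `O=C(NC(=S)NNc1ncnc2ccccc12)c1ccc(F)cc1` share another. The difference between the two cores is not broken down here. In a functional assay on CNE-2 cells (Homo sapiens) for cytotoxicity, read by MTT assay, with a stated time of 72 h (a higher number here means a weaker inhibitor, a lower number a stronger inhibitor), compound 1 gives 8410 nM and compound 2 gives 16100 nM. The change between them is 4-fluorophenyl in place of 2-methoxyphenyl on a carbonyl carbon and the step it made was a 1.9-fold higher number from compound 1 to compound 2 (0.28 log units; within the scatter). In this assay compound 3 gives 15700 nM; the values of compound 3 and compound 2 lie within the scatter of each other, as do those of compound 3 and compound 1.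

Compound 4 is not yet measured. The change from compound 3 to compound 4 is 4-fluorophenyl in place of 2-methoxyphenyl on a carbonyl carbon, the same change as from compound 1 to compound 2, occurring twice among the compounds shown. The expectation rests on a single earlier instance, so it is loose. For compound 4 in this assay the expected step is a 1.8-fold higher number from compound 3 to compound 4 (0.25 log units; within the scatter), on the basis that compound 1 to compound 2 gave a 1.9-fold higher number from compound 1 to compound 2 (0.28 log units; within the scatter). Compound 4 is therefore estimated at 28000 nM, with a likely range from 14000 nM to 60000 nM.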

Compound 4, half-maximal inhibitory concentration: 2840 nM
Compound 4: the middle estimate sits 9.9-fold (0.99 log units) above what was measured, and the stated range ends above it.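

In this assay, placing 4-fluorophenyl in place of 2-methoxyphenyl on a carbonyl carbon gave a 5.5-fold lower number from compound 3 to compound 4 (0.74 log units; beyond the scatter). The step therefore did not carry over unchanged from the core of compound 1 to the core of compound 3: the same change on two cores in this assay, a 1.9-fold higher number (0.28 log units; within the scatter) from compound 1 to compound 2 and a 5.5-fold lower number (0.74 log units; beyond the scatter) from compound 3 to compound 4, 11-fold (1.02 log units) apart, beyond the scatter of two such steps. This shows that, for these two cores, the size of the step on one core does not predict its size on the other, but with a single pair on each core it does not show which part of the core difference goes with the gap, nor whether the gap would recur with any other replacement.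

The compounds shown leave open whether other groups on the carbonyl carbon, such as unsubstituted phenyl, 4-chlorophenyl or a short alkyl chain, would also give different steps on the two cores. They also leave open whether a basic amine or a carboxylic acid at that place would follow either core's step.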